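Methyl for Cyclopropyl on the Amide Nitrogen

The source may hold more compounds than are shown below. What is called first, only, known or untested is meant among the compounds shown, and "the series" means these compounds.

Of the compounds shown here, two sharing one core have been measured in an assay on isolated protein for inhibition of Rho-associated protein kinase 2 (Homo sapiens); on this read-out higher numbers stand for weaker inhibition and lower numbers for stronger inhibition. Compound 1 `COc1cccc(CNC(=O)c2cc3ccc(-c4cn[nH]c4)nc3n2CC2CC2)c1` gives 150 nM in this assay. Compound 2 `COc1cccc(CN(C(=O)c2cc3ccc(-c4cn[nH]c4)nc3[nH]2)C2CC2)c1` gives 8 nM in this assay, the lower of the two numbers, and the gap between compound 2 and compound 1 lies well beyond the usual scatter. Going by the values given here, the two structures differ in more than one place, so no single step between them is described here.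

Compound 3 `COc1cccc(CN(C)C(=O)c2cc3ccc(-c4cn[nH]c4)nc3[nH]2)c1` is not yet measured. It differs from compound 2 by methyl in place of cyclopropyl on an amide-type nitrogen. Among the compounds with values here, no measured pair shows this exchange, so the expectation rests on compound 2 alone. The exchange is small, and the step from compound 2 to compound 3 is expected to be modest, a 1.9-fold higher number from compound 2 to compound 3 (0.27 log units; within the scatter), with a slight rise in the number more likely than a fall. Compound 3 is therefore estimated at 15 nM in this assay, expected to lie between 5 nM and 50 nM.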

Compound 3, half-maximal inhibitory concentration: 4 nM
Compound 3: the middle estimate sits 3.8-fold (0.57 log units) above what was measured; the measured number lies below the stated range.
By their numbers in this assay, from the lowest: compounds 3 and 2 (each within the scatter of the next); then compound 1.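

In this assay the exchange of cyclopropyl for methyl on the amide-type nitrogen gives a 2.0-fold lower number from compound 2 to compound 3 (0.30 log units; within the scatter) and so leaves compound 2 and compound 3 within the scatter of each other. At this place, then, the three-membered ring is not required to keep the number in the range of compound 2, and methyl serves as well as cyclopropyl on this read-out. Nothing at hand bears on why the two groups read alike.

From the compounds shown here alone, it remains open whether this nitrogen would accept the amide hydrogen in place of methyl, or a larger group such as isopropyl, benzyl or a longer chain ending in an amine. Compound 1 differs from compound 2 and compound 3 in more than one place, so steps to it cannot be read.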